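The source may hold more compounds than are shown below. What is called first, only, known or untested is meant among the compounds shown, and "the series" means these compounds.

Three compounds have been measured in a functional assay on VCaP cells (Homo sapiens) for antiproliferative activity, read by propidium iodide staining, with a stated time of 96 h; on this read-out higher numbers stand for weaker inhibition and lower numbers for stronger inhibition:

compound 1, `CC(O)(CSc1ccc(F)cc1)C(=O)Nc1ccc(S(F)(F)(F)(F)F)cc1`, 23000 nM
compound 2, `CC(O)(CSc1ccc(C(F)(F)F)cc1)C(=O)Nc1ccc(S(F)(F)(F)(F)F)cc1`, 24800 nM
compound 3, `CC(O)(CS(=O)(=O)c1ccc(F)cc1)C(=O)Nc1ccc(S(F)(F)(F)(F)F)cc1`, 34200 nM

Compound 1 and compound 2 differ by one change, (trifluoromethyl in place of fluoro on an aromatic carbon), and this change made a step of a 1.1-fold higher number from compound 1 to compound 2 (0.03 log units; within the scatter). Compound 3 rests on a different core; how its core differs from the core of compound 1 is not broken down here. Compound 4, `CC(O)(CS(=O)(=O)c1ccc(C(F)(F)F)cc1)C(=O)Nc1ccc(S(F)(F)(F)(F)F)cc1`, has not yet been measured in this assay. It differs from compound 3 by trifluoromethyl in place of fluoro on an aromatic carbon, the same change as from compound 1 to compound 2, at a place described in the same words. Compound 4 is expected to show a step of a 1.1-fold higher number from compound 3 to compound 4 (0.05 log units; within the scatter) because the same change earlier gave a 1.1-fold higher number from compound 1 to compound 2 (0.03 log units; within the scatter). Compound 4 is therefore estimated at 38000 nM, with a likely range from 15000 nM to 95000 nM.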

Compound 4, half-maximal inhibitory concentration: 27700 nM
Estimate against measurement, compound 4: 1.4-fold (0.14 log units) above; measured number inside the range.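

In this assay, trifluoromethyl in place of fluoro gave a 1.2-fold lower number from compound 3 to compound 4 (0.09 log units; within the scatter), so on the core of compound 3, as on the core of compound 1, the swap leaves the number within the scatter. The two cores give the same answer for this swap: the same change on two cores in this assay, a 1.1-fold higher number (0.03 log units; within the scatter) from compound 1 to compound 2 and a 1.2-fold lower number (0.09 log units; within the scatter) from compound 3 to compound 4, 1.3-fold (0.12 log units) apart, within the scatter of two such steps. This shows that a change with no readable effect on one core also had none on the other; it does not show that a change with a clear effect would carry over, and neither step is large enough to test that.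

The compounds shown carry only fluoro or trifluoromethyl at this place. Going by these compounds, it remains open how an amine, a carboxylic acid or a longer chain there would behave, and whether either core would then respond beyond the scatter.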